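Triazole aryl swap: nitrile in place of acetamide

The compounds below may be only part of what the source reports. "The series", "measured", "known", "first", "only" and "open" are said of these compounds alone.

Three analogues of one shared core carry different aryl groups on the triazole nitrogen. Compound 1 `COc1ccc(-n2cc(COc3c(/C=C\C(=O)O)ccc(OC)c3CC=C(C)C)nn2)cc1` has "not determined" (no result reported) in a functional assay on COLO 205 cells (Homo sapiens) for cytotoxicity, read by MTT assay, with a stated time of 24 h (on this read-out lower numbers stand for stronger inhibition and higher numbers for weaker inhibition), so no number is available for it. Going by the values given here, compound 2 `COc1ccc(/C=C\C(=O)O)c(OCc2cn(-c3cccc([N+](=O)[O-])c3)nn2)c1CC=C(C)C` gives 6900 nM, and compound 3 `COc1ccc(/C=C\C(=O)O)c(OCc2cn(-c3ccc(NC(C)=O)cc3)nn2)c1CC=C(C)C` gives 22600 nM, the highest of the two numbers recorded; the only measured step, a 3.3-fold higher number from compound 2 to compound 3 (0.52 log units; beyond the scatter), separates them beyond the scatter.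

Compound 4 `COc1ccc(/C=C\C(=O)O)c(OCc2cn(-c3cccc(C#N)c3)nn2)c1CC=C(C)C` differs from compound 3 by 3-cyanophenyl in place of 4-acetamidophenyl on an aromatic nitrogen. Among the compounds with values here, the one step that bears on this change is a 3.3-fold higher number from compound 2 to compound 3 (0.52 log units; beyond the scatter), in which the 4-acetamidophenyl of compound 3 replaced the 3-nitrophenyl of compound 2; the nitrile group entering here, like the nitro group of compound 2, brings an acceptor and no donor. A partial reversal of that step is therefore expected, giving a lower number for compound 4. The expected step is a 2.5-fold lower number from compound 3 to compound 4 (0.40 log units; beyond the scatter). Compound 4 is estimated at 9000 nM, within a range of 3500 nM to 25000 nM.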

Compound 4, half-maximal inhibitory concentration: 26800 nM
Beside the measured number, compound 4's estimate is 3.0-fold (0.47 log units) below it, outside the stated range (above it).
By their numbers in this assay, from the lowest: compound 2; then compounds 3 and 4 (each within the scatter of the next).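

With a 1.2-fold higher number from compound 3 to compound 4 (0.07 log units; within the scatter), 3-cyanophenyl in place of 4-acetamidophenyl on the aromatic nitrogen leaves the two compounds inseparable in this assay, although the entering group has no hydrogen-bond donor. The change that does register is cyano in place of nitro on an aromatic carbon, with a 3.9-fold higher number from compound 2 to compound 4 (0.59 log units; beyond the scatter), so the nitrile does not reproduce the number of the nitro compound in this assay. Compound 4 therefore goes against any reading in which an aryl group with an acceptor and no donor is enough to match compound 2.

Nothing measured here explains why the nitro and cyano compounds differ. Going by these compounds, whether an amine or a carboxylic acid on this aryl ring would side with compound 2 or with compound 3 and compound 4 remains open.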